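The compounds below may be only part of what the source reports. "The series", "measured", "known", "first", "only" and "open" are said of these compounds alone.

Compound 1 `CC(C)=CCC/C(C)=C\CCC(C)=CCNCCCN` 32100 nM
Compound 2 `CC(C)=CCC/C(C)=C\CCC(C)=CCNCCCN(C)CCCN` 10500 nM
Compound 3 `CC(C)=CCC/C(C)=C\CCC(C)=CCNCCCNCCCCNCCCN` not yet measured

In a toxicity assay on CHO cells (Cricetulus griseus) for cytotoxicity, read by WST assay, with a stated time of 24 h (a lower number here means a stronger inhibitor, a higher number a weaker inhibitor), compound 1 at 32100 nM stands highest of the two numbers. Compound 3 differs from compound 1 through 4-((3-aminopropyl)amino)butyl in place of hydrogen on an amine nitrogen and no other change. Among the compounds with values here, the only measured step bearing on this is a 3.1-fold lower number from compound 1 to compound 2 (0.49 log units; beyond the scatter) and it is modest, and it also adds an amine-bearing chain. A step of similar size or somewhat larger, toward a lower number, is therefore expected in this assay for this change. For compound 3 an estimate of 8000 nM is expected, with a range from 2500 nM to 20000 nM around it. The expected step is a 4.0-fold lower number from compound 1 to compound 3 (0.60 log units; beyond the scatter) on this estimate.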

Compound 3, half-maximal inhibitory concentration: 143000 nM
Estimate against measurement, compound 3: 18-fold (1.25 log units) below; the whole stated range lies below it.
By their numbers in this assay, from the lowest: compound 2; then compound 1; then compound 3.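

In this assay, 4-((3-aminopropyl)amino)butyl in place of hydrogen on an amine nitrogen gives a step upward (a 4.5-fold higher number from compound 1 to compound 3 (0.65 log units; beyond the scatter)), whereas the earlier amine-bearing chain gave a step downward (a 3.1-fold lower number from compound 1 to compound 2 (0.49 log units; beyond the scatter)). Adding an amine-bearing chain to the core of compound 1 therefore does not move the number in one fixed direction. Nothing available accounts for this reversal. The compounds shown leave open whether a plain butyl chain without the added amines would raise the number, and what a carboxylic acid in place of the terminal amine would do.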